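Piperidine carbamate variation on the shared core

The source may report more compounds than this note shows. Statements on the series, on what has been measured and on what is new or still open speak of the compounds shown alone.

Measured so far:
compound 1, `CC(C)(C)COC(=O)N1CCC(Oc2ncnc3c2CCN3c2ccc(S(C)(=O)=O)cc2F)CC1`, 39.8 nM
compound 2, `CC(C)SC(=O)N1CCC(Oc2ncnc3c2CCN3c2ccc(S(C)(=O)=O)cc2F)CC1`, 10 nM

Within the data shown here, compound 2 holds the lowest of the two numbers in a functional assay on CHO-K1 cells for agonist activity at Glucose-dependent insulinotropic receptor (Homo sapiens), read by a luciferase reporter, with a stated time of 5 h; on this read-out higher numbers stand for an effect only at larger amounts of compound and lower numbers for an effect already at smaller amounts; compound 1 sits one step away, and that step, a 4.0-fold lower number from compound 1 to compound 2 (0.60 log units; beyond the scatter), is the only measured change. It exchanged a neopentyloxy for an isopropylsulfanyl on the carbonyl carbon.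

Compound 3, `CS(=O)(=O)c1ccc(N2CCc3c(OC4CCN(C(=S)Sc5ccccc5)CC4)ncnc32)c(F)c1`, is not yet measured. Relative to compound 2 the change is a group of 9 heavy atoms (7 carbon, 2 sulfur; one six-membered aromatic ring of carbon only) in place of a group of 6 heavy atoms (4 carbon, 1 oxygen, 1 sulfur; no ring), on an amine nitrogen in a ring. Among the measured compounds shown here, the one known step bears only loosely on this: it touched the same carbonyl group, but the present change also replaces the carbonyl and adds a ring, so its direction is not settled by the data. A shift in either direction of a size comparable to the known step is plausible; the expectation is therefore a modest step, a 2.5-fold higher number from compound 2 to compound 3 (0.40 log units; beyond the scatter), carrying wide uncertainty.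

Compound 3 is estimated at 25 nM in this assay, with a range of 6 nM to 100 nM.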

Compound 3, half-maximal effective concentration: 12.6 nM
The estimate for compound 3 lay 2.0-fold (0.30 log units) above the measured number, and the stated range covers the measured number.
By their numbers in this assay, from the lowest: compounds 2 and 3 (each within the scatter of the next); then compound 1.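

In this assay, the amine nitrogen in the ring accommodates a group with a six-membered aromatic ring of carbon only in place of (isopropylsulfanyl)carbonyl, with the two numbers lying within the scatter of each other (a 1.3-fold higher number from compound 2 to compound 3 (0.10 log units; within the scatter)). The same group also remains clear of the neopentyloxy-bearing group of compound 1 (a 3.2-fold lower number from compound 1 to compound 3 (0.50 log units; beyond the scatter)), so among the three compounds shown, both sulfur-containing groups sit apart from the all-oxygen carbamate. No measured evidence on hand accounts for these numbers.

The aromatic ring, the thiocarbonyl and the sulfur link enter together in compound 3, so their separate contributions remain unresolved. Also open, on these data alone, is how a phenoxycarbonyl, a urea or a pyridine ring at this nitrogen would read in this assay.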